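Amide variation on a bis-sulfonyl piperidine series

A few compounds are considered here, and "the series" means these few. Any claim that something is new, unique, unknown or untested is made for them only; others in the source may bear on it.

Measured so far:
- compound 1 `CCN(CC)S(=O)(=O)c1ccc(S(=O)(=O)N2CCC[C@@H](C(=O)N3CCC(O)CC3)C2)cc1`: 230 nM
- compound 2 `CCN(CC)S(=O)(=O)c1ccc(S(=O)(=O)N2CCC[C@@H](C(=O)N[C@H]3CC[C@@H](OC)CC3)C2)cc1`: 590 nM
- compound 3 `CCN(CC)S(=O)(=O)c1ccc(S(=O)(=O)N2CCC[C@@H](C(=O)N3CCC(F)(F)CC3)C2)cc1`: 19 nM

All three values come from a functional assay on MIA PaCa-2 cells (Homo sapiens) for inhibition, read by MTT assay, with a stated time of 3 days; on this read-out lower numbers stand for stronger inhibition and higher numbers for weaker inhibition. Compound 1 holds the second highest number of the three; the nearest neighbour is compound 2 with a 2.6-fold higher number from compound 1 to compound 2 (0.41 log units; beyond the scatter), while compound 3 sits furthest away with a 12-fold lower number from compound 1 to compound 3 (1.08 log units; beyond the scatter). Compound 3 also stands well apart from compound 2, with a 31-fold lower number from compound 2 to compound 3 (1.49 log units; beyond the scatter).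

Compound 4 `CCN(CC)S(=O)(=O)c1ccc(S(=O)(=O)N2CCC[C@@H](C(=O)N[C@@H]3CCOC3)C2)cc1` carries the change ((oxolan-3-yl)amino in place of 4-hydroxypiperidin-1-yl on a carbonyl carbon). Within the data shown here, the only measured step that touches the same position in a comparable way is the one from the cyclic tertiary amide of compound 1 to the secondary amide of compound 2, a 2.6-fold higher number from compound 1 to compound 2 (0.41 log units; beyond the scatter), a modest rise. Among the measured compounds shown here, compound 4 likewise exchanges the cyclic tertiary amide for a secondary amide with a saturated oxygen-bearing ring, so a shift of similar size and direction is expected in this assay , while the large drop seen with compound 3 has no counterpart here.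

Compound 4 is therefore estimated at 450 nM, with a range of 150 nM to 1300 nM, corresponding to an expected step of a 2.0-fold higher number from compound 1 to compound 4 (0.29 log units; within the scatter).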

Compound 4, half-maximal inhibitory concentration: 100 nM
For compound 4 the middle estimate is 4.5-fold (0.65 log units) above the measured one; measured number outside the range, below it.
By their numbers in this assay, from the lowest: compound 3; then compound 4; then compound 1; then compound 2.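

In this assay, a secondary amide on this carbonyl carbon does not by itself bring a higher number than the 4-hydroxypiperidin-1-yl amide: the (oxolan-3-yl)amino group moves the opposite way to the 4-methoxycyclohexyl amide of compound 2 (a 2.3-fold lower number from compound 1 to compound 4 (0.36 log units; beyond the scatter)). With the amide-type nitrogen kept, the ring on it alone shifts the result beyond the scatter (a 5.9-fold lower number from compound 2 to compound 4 (0.77 log units; beyond the scatter)), so the earlier contrast between compound 1 and compound 2 cannot be read as a simple effect of tertiary against secondary amide, although 4,4-difluoropiperidin-1-yl still holds the lowest number of the series (a 5.3-fold higher number from compound 3 to compound 4 (0.72 log units; beyond the scatter)). No measurement at hand accounts for any of these steps.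

Open, as far as these compounds go, is whether the opposite configuration at the defined stereocentre of the oxolan-3-yl group gives a similar number, and whether the oxygen in that ring matters, which a cyclopentylamino amide would test directly. Also open, from the compounds shown here alone, is where a morpholin-4-yl or 4-fluoropiperidin-1-yl amide would fall relative to compound 3 and compound 4.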